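The compounds below may be only part of what the source reports. "The series", "measured", "known", "first", "only" and "open" are said of these compounds alone.

Measured so far in a physicochemical assay for solubility, read by spectrophotometry, in phosphate buffer, measured as kinetic solubility, with a stated time of 18 h, at pH 7.4 (a higher number here means a more soluble compound, a lower number a less soluble compound), are three compounds:
- compound 1 `O=C(Nc1ccc(F)c(-c2nc3ccccc3o2)c1)c1cc([N+](=O)[O-])ccc1Cl` at 270 nM
- compound 2 `O=C(Nc1cccc(-c2nc3ccccc3s2)c1)c1cc([N+](=O)[O-])ccc1Cl` at 580 nM
- compound 3 `O=C(Nc1cccc(-c2ccccc2)c1)c1cc([N+](=O)[O-])ccc1Cl` at 410 nM

Compound 3 lies within the usual scatter of both compound 1 and compound 2, so its place among the three numbers means little. Going on to compound 4 `O=C(Nc1cccc(-c2nc3ccccc3o2)c1)c1cc([N+](=O)[O-])ccc1Cl` puts 1,3-benzoxazol-2-yl in place of phenyl on an aromatic carbon and leaves the rest of the structure as it is.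

The nearest measured change is phenyl in place of 1,3-benzothiazol-2-yl, which gave a 1.4-fold lower number from compound 2 to compound 3 (0.15 log units; within the scatter) and so stayed small. Compound 1 carries the same 1,3-benzoxazol-2-yl group with an added fluorine on the shared core, and it gives 270 nM in this measurement. Among the compounds with values here, no measured pair shows what that fluorine does alone.

No step beyond the scatter is therefore expected, and the estimated change is a 1.0-fold lower number from compound 3 to compound 4 (0.01 log units; within the scatter) in this assay with no clear direction. The estimate for compound 4 is 400 nM with 200 nM to 800 nM as its expected range.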

Compound 4, solubility: 470 nM
Estimate against measurement, compound 4: 1.2-fold (0.07 log units) below; the measured number falls inside the stated range.
By their numbers in this assay, from the lowest: compounds 1, 3, 4 and 2 (each within the scatter of the next, the first and the last beyond it).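

Two further steps at this aromatic carbon, a 1.1-fold higher number from compound 3 to compound 4 (0.06 log units; within the scatter) and a 1.2-fold lower number from compound 2 to compound 4 (0.09 log units; within the scatter), both stay within the scatter in this assay, so phenyl, 1,3-benzothiazol-2-yl and 1,3-benzoxazol-2-yl cannot be told apart here, even though 1,3-benzoxazol-2-yl brings a five-membered aromatic ring and hydrogen-bond acceptors that phenyl lacks. Within the data shown here, the fluorine on the shared core can now be read on its own for the first time, and hydrogen in its place gives a 1.7-fold higher number from compound 1 to compound 4 (0.24 log units; within the scatter), which is also within the scatter. Nothing measured here explains these results.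

On these data alone, it remains open whether any other group at this aromatic carbon, such as an amine or a carboxylic acid, would give a step beyond the scatter. As far as these compounds go, it is also open whether swapping fluorine for hydrogen would give a similar step in compounds carrying phenyl or 1,3-benzothiazol-2-yl.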